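Swapping the Aryl Group on the Saturated Ring Carbon

The compounds below may be only part of what the source reports. "The series", "measured", "known", "first", "only" and "open" are said of these compounds alone.

Compound 1 `O=C1CC(c2cccc(Br)c2)Oc2cc(O)cc(O)c21`: 93.5%
Compound 2 `C=CCc1c(O)cc(O)c2c1OC(c1cccc(Br)c1)CC2=O`: 78.8%

Both measured compounds were tested in a functional assay on aorta (Rattus norvegicus, strain Sprague-Dawley) for inhibition, with a stated time of 20 min; on this read-out higher numbers stand for larger maximal responses and lower numbers for smaller maximal responses. Within the data shown here, compound 2 stands at the lower of the two numbers, and the only measured step, a number 14.7 percentage points lower from compound 1 to compound 2 (beyond the scatter), concerns the allyl group on the aromatic ring and leaves the aryl group on the saturated ring carbon untouched. Compound 3 `C=CCc1c(O)cc(O)c2c1OC(c1ccc(Cl)cc1)CC2=O` differs from compound 2 exactly at that aryl group: 4-chlorophenyl in place of 3-bromophenyl on a saturated ring carbon. Among the measured compounds shown here, no measured step bears on this exchange, since both measured compounds carry the same 3-bromophenyl group, so nothing here shows whether the maximal response moves up or down. The expectation therefore rests on compound 2 alone, and the step of a number 0.8 percentage points lower from compound 2 to compound 3 (within the scatter) is estimated to stay within the usual scatter. Compound 3 is expected to reach 78%, with a range from 62% to 92%.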

Compound 3, largest response reached (Emax), in percent of the reference or control that the assay uses: 77.6%
Beside the measured number, compound 3's estimate is 0.4 percentage points above it, and the stated range covers the measured number.
By their numbers in this assay, from the lowest: compounds 3 and 2 (each within the scatter of the next); then compound 1.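

In this assay, among these compounds, the exchange of 3-bromophenyl for 4-chlorophenyl on the saturated ring carbon gives a number 1.2 percentage points lower from compound 2 to compound 3 (within the scatter) and is the first measured change at this aryl group. With the allyl group in place, the maximal response therefore stays within the scatter when both the halogen and its location on the phenyl ring differ, but with both differing at once, their separate contributions cannot be told apart. Nothing measured here explains this outcome.

The compounds shown leave open whether a phenyl group carrying an amine or a carboxylic acid, or a plain phenyl group with no halogen, would give a similar maximal response at this ring carbon. They also leave open whether the same exchange would read the same on the core of compound 1, which has no allyl group.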